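The source may report more compounds than this note shows. Statements on the series, on what has been measured and on what is new or still open speak of the compounds shown alone.

Compound 1 `COc1cccc(Oc2ccc3cc(NC(=O)c4ccc(O)c(CC=C(C)C)c4)c(=O)oc3c2C)c1`: in a functional assay on MCF7 cells (Homo sapiens) for antiproliferative activity (on this read-out higher numbers stand for weaker inhibition and lower numbers for stronger inhibition), compound 1 gives 62800 nM.
Compound 2 `CC(=O)Oc1ccc(C(=O)Nc2cc3ccc(Oc4ccc(C(C)(C)C)cc4)c(C)c3oc2=O)cc1CC=C(C)C`: in this assay compound 2 gives 75000 nM.

Among these two numbers compound 2 stands highest, yet its nearest neighbour, compound 1, differs from it by an amount that lies within the usual scatter, so the two read as alike rather than ordered. Compound 3 `CC(C)=CCc1cc(C(=O)Nc2cc3ccc(Oc4ccc(C(C)(C)C)cc4)c(C)c3oc2=O)ccc1O` has not yet been measured. It differs from compound 2 in one place: hydrogen in place of acetyl on an oxygen on an aromatic ring. Compound 1 also carries the hydroxy rather than the acetoxy, though it differs from compound 3 elsewhere as well, and its number sits close to that of compound 2. For the measured compounds named here, no measured pair isolates this single change, so no step for it is known. The expected step is a 1.3-fold lower number from compound 2 to compound 3 (0.10 log units; within the scatter), small and not beyond the scatter, in no firm direction. Compound 3 is therefore expected to give about 60000 nM in this assay, within 20000 nM to 150000 nM.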

Compound 3, half-maximal inhibitory concentration: 20600 nM
Beside the measured number, compound 3's estimate is 2.9-fold (0.46 log units) above it; the measured number falls inside the stated range.
By their numbers in this assay, from the lowest: compound 3; then compounds 1 and 2 (each within the scatter of the next).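

In this assay, replacing acetoxy with hydroxy on the aromatic ring gives a 3.6-fold lower number from compound 2 to compound 3 (0.56 log units; beyond the scatter), which shows that the group on this oxygen affects the read-out, with the hydroxy form inhibiting more strongly in this pair. Compound 1 and compound 2 differ in more than one place, so they could not isolate this change. With the hydroxy kept, 4-(tert-butyl)phenyl in place of 3-methoxyphenyl on an oxygen on an aromatic ring gives a 3.0-fold lower number from compound 1 to compound 3 (0.48 log units; beyond the scatter) and shows that this second place also affects the read-out.

Going by these compounds, it remains open whether a methoxy or a longer ester such as butanoyl on the first oxygen would read like the hydroxy or like the acetoxy. Nothing shown here explains either step.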